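The compounds below may be only part of what the source reports. "The series", "measured", "known", "first", "only" and "open" are said of these compounds alone.

Three close relatives built on a shared core have been tested in a functional assay (aorta) with Oryctolagus cuniculus as the target (a higher number here means a weaker inhibitor, a lower number a stronger inhibitor), and a fourth now waits for its number.

Compound 1, `CO/C(O)=C1\C(C)=NC(C)=C(C(=O)OCCCN2C(=O)c3ccccc3S2(=O)=O)C1c1cccc([N+](=O)[O-])c1`, gives 2.6 nM in this assay. Compound 2, `CCO/C(O)=C1\C(C)=NC(C)=C(C(=O)OCCCN2C(=O)c3ccccc3S2(=O)=O)C1c1cccc([N+](=O)[O-])c1`, carries one change relative to compound 1, (methyl in place of hydrogen on a saturated chain carbon bound to an oxygen on an unsaturated carbon), and compound 2 gives 1.9 nM; the step, a 1.4-fold lower number from compound 1 to compound 2 (0.14 log units; within the scatter), stays within the scatter. Compound 3, `CCO/C(O)=C1\C(C)=NC(C)=C(C(=O)OCCCN2C(=O)c3ccccc3S2(=O)=O)C1c1cccc(Cl)c1Cl`, exchanges the aryl group on the saturated ring carbon, and compound 3 gives 1.8 nM in this assay, so that the step of a 1.1-fold lower number from compound 2 to compound 3 (0.02 log units; within the scatter) likewise lies within the scatter. The difference between the core of compound 1 and the core of compound 3 is not broken down here; their two values alone show that they sit close together.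

Compound 4, `CC1=NC(C)=C(C(=O)OCCCN2C(=O)c3ccccc3S2(=O)=O)C(c2cccc(Cl)c2Cl)/C1=C(\O)OC(C)C`, differs from compound 3 by methyl in place of hydrogen on a saturated chain carbon bound to an oxygen on an unsaturated carbon and a saturated chain carbon. Going by the values given here, this is the same kind of change as the one from compound 1 to compound 2, but not the same: in the earlier case the place was a saturated chain carbon bound to an oxygen on an unsaturated carbon, whereas here that saturated chain carbon is additionally bound to a saturated chain carbon, the ethoxy becoming isopropoxy.

For compound 4 in this assay the expected step is a 1.1-fold lower number from compound 3 to compound 4 (0.05 log units; within the scatter). That expectation rests on the earlier change of the same kind, which produced only a 1.4-fold lower number from compound 1 to compound 2 (0.14 log units; within the scatter), a move within the scatter. Compound 4 is therefore estimated at 1.6 nM, with a range from 0.7 nM to 3.6 nM.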

Compound 4, half-maximal inhibitory concentration: 2.1 nM
The estimate for compound 4 lay 1.3-fold (0.12 log units) below the measured number; low and high end bracket the measured number.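

In this assay, the methyl that turns ethoxy into isopropoxy gives a 1.2-fold higher number from compound 3 to compound 4 (0.07 log units; within the scatter), so the measurements do not separate compound 4 from compound 3. Set beside the earlier change of the same kind, the two steps cannot be told apart: the same change on two cores in this assay, a 1.4-fold lower number (0.14 log units; within the scatter) from compound 1 to compound 2 and a 1.2-fold higher number (0.07 log units; within the scatter) from compound 3 to compound 4, 1.6-fold (0.20 log units) apart, within the scatter of two such steps. On these two cores, then, adding this methyl leaves the number within the scatter each time, and a small step seen on one core was also small on the other, though the two pairs offer only limited support for carrying the change across the series; the data do not show that the methyl has any real effect, that the two steps truly run in opposite directions, or that the same result would hold on other cores, and the place of the methyl is also not quite identical in the two pairs.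

From the compounds shown here alone, what stays open is how the number would respond to a larger group at this end of the chain, such as tert-butyl, benzyl or a chain ending in an amine. Also open, going by these compounds, is how isopropoxy would read with 3-nitrophenyl on the saturated ring carbon, which would give a third pair for the same change.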